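The compounds below may be only part of what the source reports. "The series", "measured", "known", "first", "only" and "open" are said of these compounds alone.

Measured so far:
compound 1 `COc1ccccc1/C=c1/[nH]c(=O)/c(=C\c2ccccc2OC)n(C)c1=O`, 7000 nM
compound 2 `C=CCn1c(=O)/c(=C\c2cccc(Cl)c2Cl)[nH]c(=O)/c1=C\c1ccccc1OC`, 2300 nM
compound 3 `C=CCn1c(=O)/c(=C\c2ccccc2OC)[nH]c(=O)/c1=C\c1ccccc1OC`, 22400 nM

In a functional assay on A549 cells (Homo sapiens) for cytotoxicity, read by CCK-8 assay, with a stated time of 72 h (a lower number here means a stronger inhibitor, a higher number a weaker inhibitor), compound 3 stands highest of the three; compound 1 lies below it by a 3.2-fold higher number from compound 1 to compound 3 (0.51 log units; beyond the scatter) and compound 2 by a 9.7-fold higher number from compound 2 to compound 3 (0.99 log units; beyond the scatter), both beyond the scatter, so compound 3 is the weakest measured inhibitor. Compound 4 `C=CCn1c(=O)/c(=C\c2ccccc2F)[nH]c(=O)/c1=C\c1ccccc1OC` differs from compound 3 by fluoro in place of methoxy on an aromatic carbon. Among the compounds with values here, only one measured step touches this aryl group: a 9.7-fold higher number from compound 2 to compound 3 (0.99 log units; beyond the scatter), a modest rise in number on going from 2,3-dichlorophenyl to 2-methoxyphenyl. Returning to a halogen-bearing ring, though with a single fluoro, is expected to give a modest drop, a 2.5-fold lower number from compound 3 to compound 4 (0.40 log units; beyond the scatter). Compound 4 is therefore estimated at 9000 nM, within 3000 nM to 25000 nM.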

Compound 4, half-maximal inhibitory concentration: "not active" (no number reported)
Nothing numeric was reported for compound 4; the estimate stays without a comparison.
By their numbers in this assay, from the lowest: compound 2; then compound 1; then compound 3.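

In this assay, within the data shown here, compound 4 is reported as "not active" without a number, so no step from compound 3 to compound 4 can be read. The compounds shown leave open how 2-fluorophenyl ranks numerically against 2-methoxyphenyl and 2,3-dichlorophenyl. No supporting data bear on this result.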